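Swapping the cyano-aryl amine on a thienopyrimidine and a pyrrolopyrimidine

The compounds below may be only part of what the source reports. "The series", "measured", "known", "first", "only" and "open" are said of these compounds alone.

Compound 1 `Cc1cc(-c2ccc(F)cc2)cc(C)c1Oc1nc(Nc2ccc(C#N)c(F)c2)nc2sccc12` and compound 2 `Cc1cc(-c2ccc(F)cc2)cc(C)c1Oc1nc(Nc2ccc(C#N)nc2)nc2sccc12` share one core and differ only at one nitrogen on an aromatic ring. In a toxicity assay on MT4 cells (Homo sapiens) for cytotoxicity, read by MTT assay, with a stated time of 5 days (on this read-out lower numbers stand for higher toxicity in this test and higher numbers for lower toxicity in this test), compound 1 gives 28900 nM and compound 2 gives 2230 nM. The change is 6-cyanopyridin-3-yl in place of 4-cyano-3-fluorophenyl on a nitrogen on an aromatic ring, and it made a 13-fold lower number from compound 1 to compound 2 (1.11 log units; beyond the scatter), so the pyridine-bearing compound 2 was read as more toxic in this assay.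

Compound 3 `Cc1cc(/C=C/C#N)cc(C)c1Oc1nc(Nc2ccc(C#N)c(F)c2)nc2cc[nH]c12` is built on a different core; the difference between the two cores is not broken down here. In this assay compound 3 gives 188000 nM, the highest of the three numbers and therefore the least toxic of the three measured compounds.

Compound 4 `Cc1cc(/C=C/C#N)cc(C)c1Oc1nc(Nc2ccc(C#N)nc2)nc2cc[nH]c12` carries the same kind of change on the core of compound 3: 6-cyanopyridin-3-yl in place of 4-cyano-3-fluorophenyl on a nitrogen on an aromatic ring. The place of the change, a nitrogen on an aromatic ring whose other neighbour is an aromatic carbon, reads the same in both pairs, so the two changes are the same change on two different cores. Among the measured compounds shown here, only one measured example of this change exists, so its size on the new core is uncertain. Compound 4 is expected to give roughly 25000 nM, in a range from 7000 nM to 90000 nM, resting on compound 3 with 188000 nM and on the step of a 13-fold lower number from compound 1 to compound 2 (1.11 log units; beyond the scatter). The step expected is a 7.5-fold lower number from compound 3 to compound 4 (0.88 log units; beyond the scatter), taken somewhat smaller than the measured one since it rests on a single pair.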

Compound 4, half-maximal cytotoxic concentration: 7940 nM
The estimate for compound 4 lay 3.1-fold (0.50 log units) above the measured number; the measured number falls inside the stated range.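

On the core of compound 3, putting 6-cyanopyridin-3-yl in place of 4-cyano-3-fluorophenyl again lowered the number in this assay, and it made a 24-fold lower number from compound 3 to compound 4 (1.37 log units; beyond the scatter), so the pyridine-bearing compound 4 was read as the more toxic of the two. Set beside the earlier pair, the change carried over to the second core in direction and, as far as two pairs can tell, in size: the same change on two cores in this assay, a 13-fold lower number (1.11 log units; beyond the scatter) from compound 1 to compound 2 and a 24-fold lower number (1.37 log units; beyond the scatter) from compound 3 to compound 4, 1.8-fold (0.26 log units) apart, within the scatter of two such steps. Among the compounds shown here, this shows that in these two pairs the swap behaved as one transferable step, so a step measured on one core gave a usable guide to the other, but it rests on only two pairs and does not show that a third core would follow, nor does it explain why the number falls.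

The compounds shown leave open how much of the step comes from the ring nitrogen and how much from the loss of the fluorine, which a 4-cyanophenyl group on the same nitrogen could help to separate. They also leave open whether the step would survive if the nitrile were replaced by an amide or a carboxylic acid.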